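This account rests on a few compounds, and the source may have more. Where it says the series, first, only, none or still open, it means among the compounds named here.

In a functional assay on HEK293 cells (Homo sapiens) for cytotoxicity (a higher number here means that more compound is tolerated, a lower number that less compound is tolerated), compound 1 (`COc1ccc([C@H]2CC(=O)N(c3ccccc3)C2)cc1OC1CCCC1`) gives > 10000 nM as a limit and not a number. Compound 2 (`COc1ccc([C@H]2CC(=O)N(c3cccc(N(C)C)c3)C2)cc1OC1CCCC1`) also gives > 10000 nM as a limit. Compound 3 (`COc1ccc([C@H]2CC(=O)N(c3cccc(NCCCc4ccccc4)c3)C2)cc1OC1CCCC1`) gives > 10000 nM as a limit too, so it has no number of its own and sits with the others (the limit of > 10000 nM in this assay, at which 3 of the 3 values shown sit). Compound 4 (`COc1ccc([C@H]2CC(=O)N(c3cccc(NS(=O)(=O)c4cc(C)ccc4OC)c3)C2)cc1OC1CCCC1`) differs from compound 3 in one change ((2-methoxy-5-methylphenyl)sulfonyl in place of 3-phenylpropyl on a nitrogen on an aromatic ring), with a sulfonyl group now on that nitrogen. The measured steps that bear on this (a step that the two limits leave unreadable from compound 1 to compound 2 and a step that the two limits leave unreadable from compound 1 to compound 3 and a step that the two limits leave unreadable from compound 2 to compound 3) offer no size to carry over. The step expected in this assay is therefore a number no higher from compound 3 to compound 4 (the limit leaves the size open) and these data set no direction for it. For compound 4 the estimate is 10000 nM (expected range 5000 nM to 20000 nM).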

Compound 4, half-maximal cytotoxic concentration: > 10000 nM
Compound 4: no number, only a limit; the forecaster's own chance of this, stated with the estimate: 80%; the middle value sits exactly at the limit.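

For the compounds shown here, compound 3 and compound 4 each give only a limit in this assay, so no step between them can be read: the limit of > 10000 nM in this assay, at which 4 of the 4 values shown sit. The compounds shown leave open at what concentration, if any, each one becomes toxic to these cells.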